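The source may report more compounds than this note shows. Statements on the series, on what has been measured and on what is new or still open speak of the compounds shown alone.

The measured compounds:

Compound 1 `O=C(Nc1cccc(-n2cc(-c3ccncc3)c(-c3ccc(Cl)c(O)c3)n2)c1)Nc1cccc(C(F)(F)F)c1` — in a functional assay on A549 cells (Homo sapiens) for inhibition, read by sulforhodamine B assay, with a stated time of 48 h (on this read-out higher numbers stand for weaker inhibition of growth and lower numbers for stronger inhibition of growth), compound 1 gives > 32500 nM, which is a limit of the assay and not a number.
Compound 2 `O=C(Nc1cccc(-n2cc(-c3ccncc3)c(-c3ccc(Cl)c(O)c3)n2)c1)Nc1ccc(Cl)c(Cl)c1` — compound 2 gives > 32500 nM, likewise a limit.
Compound 3 `COc1cc(-c2nn(-c3cccc(NC(=O)Nc4cccc(C(F)(F)F)c4)c3)cc2-c2ccncc2)ccc1Cl` — compound 3 gives > 50000 nM, also a limit.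

Compound 1 therefore stands only at a limit, as do the two other compounds shown, so none of the three can be placed on a scale relative to the others. The step from compound 1 to compound 4 `O=C(Nc1cccc(-n2cc(-c3ccncc3)c(-c3ccc(Cl)c(O)c3)n2)c1)Nc1cc(C(F)(F)F)cc(C(F)(F)F)c1` is trifluoromethyl in place of hydrogen on an aromatic carbon. Among the compounds with values here, two measured steps touch the same compound: a step that the two limits leave unreadable from compound 1 to compound 2 and a step that the two limits leave unreadable from compound 1 to compound 3. Neither gives a readable size, since both ends sit at limits, as summarised in the limit of > 32500 nM in this assay, at which 2 of the 3 values shown sit, and (the limit of > 50000 nM in this assay, at which 1 of the 3 values shown sits). Within the data shown here, no measured step therefore shows a direction for the change to compound 4, and no step beyond the scatter can be predicted in this assay. Compound 4 is expected to give 40000 nM, with a range from 15000 nM to 100000 nM, most probably as a further limit. The expected step that the limit leaves unreadable from compound 1 to compound 4 is accordingly estimated as none beyond the scatter.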

Compound 4, concentration for total growth inhibition: 1690 nM
For compound 4 the middle estimate is 24-fold (1.37 log units) above the measured one; the measured number lies below the stated range.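

In this assay, within the data shown here, adding trifluoromethyl on an aromatic carbon, meta to a large group and meta to the trifluoromethyl group already on that ring, gives the first step that can be read: an at least 19-fold lower number from compound 1 to compound 4 (1.28 log units; beyond the scatter). The earlier steps shown here, to the 3,4-dichlorophenyl group and to methyl on the oxygen, cannot be read, so they did not show whether any single change could bring the series off its limits; compound 4 shows that a change on this ring alone can. Compound 4 is also the only compound shown that gives a number rather than a limit: the limit of > 32500 nM in this assay, at which 2 of the 4 values shown sit.

With a single readable step, the compounds shown do not tell whether the gain depends on trifluoromethyl itself or on any group at this place, such as a nitrile, a tert-butyl group or a simple chlorine. They also leave open whether the hydroxyl of the chlorophenyl ring is still tolerated as its methyl ether, or replaceable by an amine, once this ring carries both trifluoromethyl groups.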